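Spiro-amide series: replacing the piperidine amide with an aminobutyl amide

This account rests on a few compounds, and the source may have more. Where it says the series, first, only, none or still open, it means among the compounds named here.

Three members of the series have numbers in an assay on HEK293 cells for displacement of a labelled ligand from NPC1-like intracellular cholesterol transporter 1 (Homo sapiens); a lower number here means a stronger inhibitor, a higher number a weaker inhibitor. Compound 1 `CC(C)(C)c1ccc(C(=O)N2CCC3(CC2)C(=O)N(CC(=O)N2CCCCC2CCO)CN3c2ccccc2)cc1` gives 6100 nM. Compound 2 `CC(C)(C)OC(=O)NCCCCNC(=O)CN1CN(c2ccccc2)C2(CCN(C(=O)c3ccc(C4CCCCC4)cc3)CC2)C1=O` gives 4600 nM, and compound 3 `CC(C)(C)OC(=O)N1CCN(C(=O)CN2CN(c3ccccc3)C3(CCN(C(=O)c4ccc(C5CCCCC5)cc4)CC3)C2=O)CC1` gives 3500 nM. The numbers of compounds 1, 2 and 3 lie within the usual scatter of one another, so no ranking among them is supported.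

Compound 4 `CC(C)(C)c1ccc(C(=O)N2CCC3(CC2)C(=O)N(CC(=O)NCCCCN)CN3c2ccccc2)cc1` is built from compound 1 by one change: (4-aminobutyl)amino in place of 2-(2-hydroxyethyl)piperidin-1-yl on a carbonyl carbon. Among the compounds with values here, no measured pair isolates this change. Compound 2 carries a related (4-aminobutyl)amino chain and shows 4600 nM, so only a small step is expected, a 1.5-fold lower number from compound 1 to compound 4 (0.18 log units; within the scatter), not beyond the scatter. Compound 4 is estimated at 4000 nM, with a range from 1500 nM to 12000 nM.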

Compound 4, half-maximal inhibitory concentration: 14500 nM
The estimate for compound 4 lay 3.6-fold (0.56 log units) below the measured number, and the stated range ends below it.
By their numbers in this assay, from the lowest: compounds 3, 2 and 1 (each within the scatter of the next); then compound 4.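

Within the data shown here, the change from 2-(2-hydroxyethyl)piperidin-1-yl to (4-aminobutyl)amino on a carbonyl carbon gives a 2.4-fold higher number from compound 1 to compound 4 (0.38 log units; beyond the scatter) in this assay and is the first step beyond the scatter. This position therefore does not treat these two amides alike, and the piperidine amide of compound 1 is the better of the pair, though only modestly. Nothing available explains the rise.
Still open, on these data alone, is whether the loss follows the terminal amine or the missing ring. A plain piperidin-1-yl amide, or a butyl chain ending in a hydroxyl or a carboxylic acid, would separate the two.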